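The source may report more compounds than this note shows. Statements on the series, on what has been measured and on what is new or still open speak of the compounds shown alone.

Going by the values given here, in an ADME assay on MRC5 cells (Homo sapiens) for cytotoxicity, read by neutral red uptake, with a stated time of 24 h (on this read-out higher numbers stand for weaker inhibition and lower numbers for stronger inhibition), compound 1 `CC(C)C(=O)Oc1c(C(C)C)cc2c3c1OC(=O)[C@@]31CCCC(C)(C)[C@@H]1CC2` gives 119000 nM, the lower of the two numbers measured so far, while compound 2 `CCCCC/C=C/C/C=C/CCCCCCCC(=O)Oc1c(C(C)C)cc2c3c1OC(=O)[C@@]31CCCC(C)(C)[C@@H]1CC2` gives 293000 nM, a gap beyond the usual scatter. Compound 3 `CC(C)c1cc2c3c(c1OC(=O)Cc1c[nH]c4ccccc14)OC(=O)[C@@]31CCCC(C)(C)[C@@H]1CC2` keeps the core of compound 1 and changes in one place: (1H-indol-3-yl)methyl in place of isopropyl on a carbonyl carbon, with (1H-indol-3-yl)methyl in place of isopropyl on a carbonyl carbon. Among the compounds with values here, no measured step shows this change, so only a small expected move towards a higher number, within the scatter, is assumed: a 1.3-fold higher number from compound 1 to compound 3 (0.13 log units; within the scatter). The estimated value for compound 3 is 160000 nM, with an expected range of 60000 nM to 400000 nM.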

Compound 3, half-maximal inhibitory concentration: 109000 nM
Beside the measured number, compound 3's estimate is 1.5-fold (0.17 log units) above it, and the stated range covers the measured number.
By their numbers in this assay, from the lowest: compounds 3 and 1 (each within the scatter of the next); then compound 2.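

In this assay, putting the much larger (1H-indol-3-yl)methyl in place of isopropyl on a carbonyl carbon gives a 1.1-fold lower number from compound 1 to compound 3 (0.04 log units; within the scatter) and so shows that this place can carry two aromatic rings and a hydrogen-bond donor with no readable shift in the number. The earlier compounds shown here offered no step that could be read as a single change here. No measurement available here accounts for this result.

The compounds shown leave open whether an amine or a carboxylic acid at this place would move the number. They also leave open how a simple methyl would compare.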